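From 4-nitrobenzyl to 3-cyanobenzyl on a shared core

This account rests on a few compounds, and the source may have more. Where it says the series, first, only, none or still open, it means among the compounds named here.

In a functional assay on a cell-free system (plasma, Oryctolagus cuniculus) for inhibition, with stated times of 5 min, 1 min and 6 min (on this read-out lower numbers stand for stronger inhibition and higher numbers for weaker inhibition), compound 1 `CCOC(=O)c1c(C)nc(-c2cccc(C#N)c2)n1O` gives 17600 nM. Compound 2 `CCOC(=O)c1c(C)nc(-c2cccc(C#N)c2)n1OCc1ccc([N+](=O)[O-])cc1`, which carries a 4-nitrobenzyl in place of hydrogen on an oxygen on an aromatic ring, gives 8750 nM. For the measured compounds named here, these are the only two numbers so far, and they lie within the scatter of each other, so neither compound can be ranked above the other. The measured change is a 2.0-fold lower number from compound 1 to compound 2 (0.30 log units; within the scatter).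

Compound 3 `CCOC(=O)c1c(C)nc(-c2cccc(C#N)c2)n1OCc1cccc(C#N)c1` keeps the shared core and changes only the outer ring: 3-cyanophenyl in place of 4-nitrophenyl on a saturated chain carbon bound to an oxygen on an aromatic ring. In words, 3-cyanophenyl stands in place of 4-nitrophenyl on a saturated chain carbon bound to an oxygen on an aromatic ring.

Going by the values given here, no measured step exchanges one such ring for another, so the evidence is thin. The closest guide is the step to compound 2, which stayed within the scatter at a 2.0-fold lower number from compound 1 to compound 2 (0.30 log units; within the scatter). No change beyond the scatter is therefore expected in this assay. The expected change is a 1.1-fold higher number from compound 2 to compound 3 (0.06 log units; within the scatter). For compound 3 the estimated value is 10000 nM, with an expected range of 3500 nM to 30000 nM.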

Compound 3, half-maximal inhibitory concentration: > 30000 nM
Compound 3 gave a limit, no number; the forecaster's own chance of this, stated with the estimate: 10%; at least 3.0-fold (0.47 log units) between middle value and limit.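

In this assay compound 3 gives only a limit of the assay, not a number: the limit of > 30000 nM in this assay, at which 1 of the 3 values shown sits.

Even so, the exchange of 4-nitrophenyl for 3-cyanophenyl on a saturated chain carbon bound to an oxygen on an aromatic ring is the first change here that goes beyond the scatter, with an at least 3.4-fold higher number from compound 2 to compound 3 (0.53 log units; beyond the scatter), so the read-out does respond to what the outer ring carries at this place, something the earlier step from hydrogen to 4-nitrobenzyl could not show. The comparison with hydrogen at the same oxygen is less firm, with an at least 1.7-fold higher number from compound 1 to compound 3 (0.23 log units; that floor lies within the scatter), so the floor of this step does not show that 3-cyanobenzyl differs from hydrogen, although the true gap may be larger.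

The step from compound 2 to compound 3 alters both the group on the outer ring, nitro to nitrile, and its place on that ring, so the two cannot be told apart. On these data alone, whether 4-cyanophenyl, 3-nitrophenyl or plain phenyl would follow compound 2 or compound 3 at this place stays open, as does the true value of compound 3.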